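A few compounds are considered here, and "the series" means these few. Any claim that something is new, unique, unknown or untested is made for them only; others in the source may bear on it.

Of the compounds shown here, three sharing one fused core have so far been tested in a functional assay (Homo sapiens) for inhibition of Nucleic Acid, tested at 100 uM; on this read-out higher numbers stand for more inhibition at the one concentration tested (going by the name of the read-out) and lower numbers for less inhibition. Compound 1, `Sc1[nH]ccc2ncnc1-2`, the smallest of the set, gives 26%. Compound 2, `CSc1nccc2c1ncn2[C@H]1C[C@H](O)[C@@H](CO)O1`, which carries a methylsulfanyl group and a sugar on the core, gives 36%. Compound 3, `OC[C@H]1OC(n2cnc3c(S)nccc32)[C@H](O)[C@@H]1O`, which carries a sulfanyl group and a different sugar, gives 6%. Compound 3 therefore stands at the bottom of the three numbers: compound 1 lies closest to it, and the gap between them is beyond the usual scatter, while compound 2 lies furthest from it, also beyond the scatter.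

The next compound, compound 4, `OCCNc1nccc2c1ncn2C1O[C@H](CO)[C@@H](O)[C@H]1O`, keeps the sugar and the core of compound 3 and differs from it in one place: (2-hydroxyethyl)amino in place of sulfanyl on an aromatic carbon. The exchange sits on an aromatic carbon of a six-membered aromatic ring with one nitrogen, next to the ring nitrogen.

Within the data shown here, no measured pair in this set differs in exactly this way, so the size of the step is open. Compound 3 sits low, and compound 2, with its sulfur capped by a methyl group, sits higher, so the expectation is a moderate rise in this assay. Compound 4 is estimated to give 20%, within a range from 2% to 48%, which would mean a step of a number 14 percentage points higher from compound 3 to compound 4 (beyond the scatter).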

Compound 4, a percentage reported as inhibition, at one concentration (the size of the read-out at that concentration, not a potency): 0%
Estimate against measurement, compound 4: 20 percentage points above, outside the stated range (below it).
By their numbers in this assay, from the lowest: compounds 4 and 3 (each within the scatter of the next); then compounds 1 and 2 (each within the scatter of the next).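

Among these compounds, the exchange of sulfanyl for (2-hydroxyethyl)amino, on an aromatic carbon next to the ring nitrogen, is the first one-place comparison in this set, and in this assay it gives a number 6 percentage points lower from compound 3 to compound 4 (within the scatter) with the sugar and the shared core unchanged. Replacing a group of 1 heavy atom with a chain of 4 heavy atoms, which has 2 hydrogen-bond donors and 2 hydrogen-bond acceptors, therefore does not shift the read-out by more than repeated measurements of the same compound would be expected to vary. No measurement shown here offers an explanation for this outcome.

Going by these compounds, whether this position responds to any other group remains open, and a simple amine or a longer chain ending in a carboxylic acid, each placed where sulfanyl sits in compound 3, would give further one-place comparisons. On these data alone, it also remains open how much of the gap between compound 2 and compound 3 belongs to the group on sulfur and how much to the sugar, since those two compounds differ in more than one place.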